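The source may hold more compounds than are shown below. What is called first, only, known or untested is meant among the compounds shown, and "the series" means these compounds.

Of the compounds shown here, two have so far been measured in a physicochemical assay for solubility, read by turbidimetry, measured as kinetic solubility, at pH 7.4; a higher number here means a more soluble compound, a lower number a less soluble compound. Compound 1, `CC(C)(C)c1cc(C(=O)Nc2ncc(CN)s2)n(Cc2ccccc2)n1`, gives 80 ug/mL in this assay. Compound 2, `Cc1cc(C(=O)Nc2nc(CN)cs2)n(Cc2ccccc2)n1`, gives 160 ug/mL in this assay. Compound 2 therefore shows the higher of the two numbers, but the gap to compound 1 lies within the scatter of repeated measurements of this kind, so the two compounds cannot be told apart on this basis.

Compound 3, `Cc1ccc(-c2cc(C(=O)Nc3nc(CN)cs3)n(Cc3ccccc3)n2)cc1`, has not yet been measured. It differs from compound 2 in one place: 4-methylphenyl in place of methyl on an aromatic carbon. Within the data shown here, no measured pair of compounds shows what this particular change does to kinetic solubility, so the expectation rests on the change itself and on the value of compound 2. Replacing a methyl by an aromatic ring of the size described is expected to bring a step downward, beyond the scatter, and the estimated step is an 8.0-fold lower number from compound 2 to compound 3 (0.90 log units; beyond the scatter). For compound 3 the expected value in this assay is 20 ug/mL, with a range from 5 ug/mL to 60 ug/mL.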

Compound 3, solubility: 40 ug/mL
Compound 3: middle estimate off by 2.0-fold (0.30 log units), on the low side; measured number inside the range.
By their numbers in this assay, from the lowest: compounds 3, 1 and 2 (each within the scatter of the next, the first and the last beyond it).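

Putting 4-methylphenyl in place of methyl on this aromatic carbon gives a 4.0-fold lower number from compound 2 to compound 3 (0.60 log units; beyond the scatter) in this assay. Among these compounds, this is the only pair here that differs in one place, so it offers the first direct reading of this position, and the step lies beyond the scatter: in this pair, what sits on this carbon is reflected in the number, and the enlarged group brings in one six-membered aromatic ring of carbon only and no hydrogen-bond donors or acceptors. No measurement here accounts for the step, so it stands as an observation about one pair, with no explanation attached.

A single pair cannot separate the contribution of the ring itself from that of its methyl, or show whether the same swap would give a similar step on a different core. An unsubstituted phenyl, a longer alkyl chain, or a ring or chain carrying an amine or a carboxylic acid on this same carbon would be needed to show how the number follows the group placed here.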